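Methoxy for chloro at the weak end of the series

This account rests on a few compounds, and the source may have more. Where it says the series, first, only, none or still open, it means among the compounds named here.

In a functional assay on MCF7 cells (Homo sapiens) for antiproliferative activity, read by sulforhodamine B assay, with a stated time of 72 h (on this read-out lower numbers stand for stronger inhibition and higher numbers for weaker inhibition), compound 1 `O=C(/C=C/c1cc2ccccc2s1)c1cc(Cl)ccc1O` gives > 10000 nM as a limit and not a number. Compound 1 thus stands at the limit of > 10000 nM in this assay, at which 1 of the 2 values shown sits, with no number of its own. Within the data shown here, compound 2 `O=C(/C=C/c1cc2ccccc2s1)c1cc(Cl)cc(Cl)c1O` gives 9900 nM in this assay as the only number so far. Compound 3 `COc1ccc(O)c(C(=O)/C=C/c2cc3ccccc3s2)c1` carries methoxy in place of chloro on an aromatic carbon para to a hydroxy group and meta to a large group. Among the measured compounds shown here, the one measured step of a number no higher from compound 1 to compound 2 (the limit leaves the size open) is a different change, chloro in place of hydrogen on an aromatic carbon, and its size stays open. It therefore offers no size to carry over, and no direction can be set in this assay for this replacement. The expected step that the limit leaves unreadable from compound 1 to compound 3 is none beyond the scatter. Compound 3 is estimated at 12000 nM in this assay with 5000 nM to 30000 nM as the expected range.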

Compound 3, half-maximal inhibitory concentration: > 10000 nM
Compound 3: only a limit was reported; the forecaster's own chance of this, stated with the estimate: 60%; the middle value lies beyond the limit too.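

In this assay compound 3 gives > 10000 nM, a limit and not a number. Among these compounds, compound 1 also gives a limit, > 10000 nM, so no step between compound 1 and compound 3 can be read. The compounds shown leave open both the size and the direction of methoxy in place of chloro on an aromatic carbon.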